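This account rests on a few compounds, and the source may have more. Where it says the series, first, only, none or still open, it means among the compounds named here.

Compound 1 `C[C@H](Oc1ccc2ncc(/C=C/C(=O)O)c(C3CC3)c2c1)c1c(Cl)cccc1Cl`: 3.7
Compound 2 `C[C@H](Oc1ccc2ncc(-c3ccn(CCC(=O)O)n3)c(C3CC3)c2c1)c1c(Cl)cccc1Cl`: 2.7
Compound 3 `C[C@H](Oc1ccc2ncc(/C=C/C(=O)O)c(C3CC3)c2c1)c1c(Cl)ccnc1Cl`: 2.3

In a physicochemical assay for lipophilicity, using the shake flask method (on this read-out higher numbers stand for higher lipophilicity and lower numbers for lower lipophilicity), compound 1 stands highest of these three. Compound 4 `O=C(O)/C=C/c1cnc2ccc(O[C@@H](CO)c3c(Cl)cccc3Cl)cc2c1C1CC1` has not yet been measured. Its structure departs from compound 1 in one place: hydroxy in place of hydrogen on a saturated chain carbon, two bonds along the chain from an aromatic carbon and an oxygen on an aromatic ring. In words, hydroxy replaces hydrogen, turning methyl into hydroxymethyl. Neither measured step makes this same change, so both are only a rough guide. Both went down, with a number 1.00 log units lower from compound 1 to compound 2 (beyond the scatter) and a number 1.40 log units lower from compound 1 to compound 3 (beyond the scatter). A downward step close to the smaller of these is therefore expected, beyond the scatter. The expected change is a number 0.90 log units lower from compound 1 to compound 4 (beyond the scatter). Compound 4 is estimated at 2.8, with an expected range from 2.3 to 3.3.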

Compound 4, distribution coefficient: 2
Compound 4: the middle estimate sits 0.80 log units above what was measured; the whole stated range lies above it.
By their numbers in this assay, from the lowest: compounds 4 and 3 (each within the scatter of the next); then compound 2; then compound 1.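

In this assay the change from methyl to hydroxymethyl gives a number 1.70 log units lower from compound 1 to compound 4 (beyond the scatter) and so shows that one added oxygen atom on this saturated chain carbon is enough for a large step. The earlier compounds shown here all carried methyl here, so they said nothing about this carbon. Nothing measured here bears on why the step is this large. Still open, going by these compounds, is whether an amine, a methoxy group or a longer chain such as hydroxyethyl on this carbon would shift the number as far. Also open, on these data alone, is whether hydroxy gives a similar step on compound 2 or compound 3.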